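The source may hold more compounds than are shown below. What is called first, only, known or untested is meant among the compounds shown, and "the series" means these compounds.

Compound 1 `CCC1(Cc2ccccc2)OS(=O)(=O)C=C1OCC#N`: > 200000 nM in an ADME assay on HEL cells (Homo sapiens) for cytotoxicity, with a stated time of 3 days; on this read-out higher numbers stand for lower toxicity in this test and lower numbers for higher toxicity in this test
Compound 2 `CCC1(Cc2ccccc2)OS(=O)(=O)CC1=O`: 200000 nM in this assay

In this assay compound 1 gives > 200000 nM, and this is a limit of the assay, not a number: the toxicity was too weak to be pinned down within the range tested. Where compound 1 stands is therefore known only as a limit, and that limit is the limit of > 200000 nM in this assay, at which 1 of the 2 values shown sits. Compound 2 gives 200000 nM in this assay. Going by the values given here, compounds 1 and 2 differ in more than one place, so no single step connects them; their two values show that both sit at the top of the range tested.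

Compound 3 `CCC1(Cc2ccccc2)OS(=O)(=O)C=C1OCc1ccc(OC)cc1` has not yet been measured. It differs from compound 1 by 4-methoxyphenyl in place of cyano on a saturated chain carbon bound to an oxygen on an unsaturated carbon. Among the compounds with values here, no measured step of this kind is available, so there is nothing to suggest a change in this assay beyond the usual scatter, and the expectation is that compound 3 also reaches the limit of the assay. Compound 3 is estimated at 200000 nM, with a range from 60000 nM to 400000 nM, which corresponds to an expected step of a number no higher from compound 1 to compound 3 (the limit leaves the size open).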

Compound 3, half-maximal cytotoxic concentration: > 200000 nM
Compound 3: a limit, no number; the forecaster's own chance of this, stated with the estimate: 60%; the middle value lies on the limit itself.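

In this assay, going by these compounds alone, compound 1 and compound 3 each give a limit of the assay rather than a number, so no step between them can be read. The compounds shown leave open how weak the toxicity of either compound really is, and whether 4-methoxyphenyl in place of cyano changes it at all.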